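The source may hold more compounds than are shown below. What is called first, only, known or untested is meant among the compounds shown, and "the series" means these compounds.

Compound 1 `Clc1ccc(CSc2nnc(-c3ccncc3)n2-c2ccccc2)cc1` in a functional assay on HCT-116 cells (Homo sapiens) for inhibition, read by MTT assay, with a stated time of 48 h (a lower number here means a stronger inhibitor, a higher number a weaker inhibitor), gives 10700 nM. Compound 2 `O=[N+]([O-])c1ccccc1CSc1nnc(-c2ccncc2)n1-c1ccccc1` in this assay gives only a limit, > 50000 nM. Compound 3 `O=C(CSc1nnc(-c2ccncc2)n1-c1ccccc1)N/N=C/c1ccc(Br)cc1` in this assay gives 4500 nM.

Among the three measured values, compound 3 stands lowest; its nearest neighbour is compound 1, and the gap between them lies beyond the usual scatter. Compound 2 contributes only a limit, noted in the limit of > 50000 nM in this assay, at which 1 of the 3 values shown sits, and one of the three values sits at it. Among the measured compounds shown here, the one measured step is the change an at least 4.6-fold higher number from compound 1 to compound 2 (0.66 log units; beyond the scatter), which concerns the group on a saturated chain carbon bound to a sulfur, not the part of the molecule that changes next.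

Compound 4 `O=C(CSc1nnc(-c2ccncc2)n1-c1ccccc1)N/N=C/c1ccc(O)c(O)c1` differs from compound 3 by 3,4-dihydroxyphenyl in place of 4-bromophenyl on a carbon with a double bond to nitrogen. For the measured compounds named here, no measured step touches this position, so the step from compound 1 to compound 2 gives at most an indication that changing the outer aromatic group can move the number considerably. With nothing closer to draw on, compound 4 is expected to land near compound 3, with a wide range to cover either direction. The estimate for compound 4 in this assay is 6000 nM, between 1800 nM and 20000 nM, and the step from compound 3 to compound 4 is expected to be a 1.3-fold higher number from compound 3 to compound 4 (0.12 log units; within the scatter).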

Compound 4, half-maximal inhibitory concentration: 14700 nM
Beside the measured number, compound 4's estimate is 2.5-fold (0.39 log units) below it; measured number inside the range.
By their numbers in this assay, from the lowest: compound 3; then compounds 1 and 4 (each within the scatter of the next). At a limit, above all of these: compound 2.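

Among the compounds shown here, the exchange of 4-bromophenyl for 3,4-dihydroxyphenyl on a carbon with a double bond to nitrogen gives a 3.3-fold higher number from compound 3 to compound 4 (0.51 log units; beyond the scatter) in this assay, so this position, which no earlier step touched, does respond to a change of its aromatic group. The six-membered aromatic ring of carbon is present on both sides of the step, and what differs is that the leaving group has no hydrogen-bond donors or acceptors while the entering group has both, so the step can be tied to the ring's substituents but not to the ring itself. Nothing available here offers an explanation for why the number moves in this direction at this position.

On these data alone, with only these two groups at this position, it remains open whether the two hydroxy groups act together or whether one alone would give the same reading, and whether an unsubstituted phenyl would read closer to compound 3 or to compound 4. Also open, as far as these compounds go, is how an amine or a carboxylic acid on that ring would read in this assay, and whether a methoxy group in place of each hydroxy group would keep or reverse the step.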